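Lengthening the chain and changing the amine on a chromone core

A few compounds are considered here, and "the series" means these few. Any claim that something is new, unique, unknown or untested is made for them only; others in the source may bear on it.

Measured so far:
compound 1, `CN(C)CCCCOc1ccc2oc(-c3ccccc3)cc(=O)c2c1` — 720 nM
compound 2, `CN(C)CCCCCCCCCCOc1ccc2oc(-c3ccccc3)cc(=O)c2c1` — 297 nM
compound 3, `O=c1cc(-c2ccccc2)oc2ccc(OCCCCCCN3CCCCC3)cc12` — 101 nM

All three were tested in an assay on isolated protein (Cavia porcellus) with Sigma non-opioid intracellular receptor 1 (Homo sapiens) as the target, read by radioligand binding; a lower number here means a stronger inhibitor, a higher number a weaker inhibitor. Compound 1 has the highest number of the three, so it is the weakest inhibitor shown; the step of a 2.4-fold lower number from compound 1 to compound 2 (0.38 log units; beyond the scatter) and the step of a 7.1-fold lower number from compound 1 to compound 3 (0.85 log units; beyond the scatter) both go beyond the scatter and both run downward, toward stronger inhibition.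

Compound 4, `CCN(CC)CCCCCCOc1ccc2oc(-c3ccccc3)cc(=O)c2c1`, has not been measured. It differs from compound 1 in one place: 2-(diethylamino)ethyl in place of dimethylamino on a saturated chain carbon, four bonds along the chain from an oxygen on an aromatic ring

Both measured steps from compound 1 bear on this. Going from compound 1 to compound 2 extends the chain between the aromatic oxygen and the amine and gives a modest gain; going from compound 1 to compound 3 extends the chain and also enlarges the amine, and gives a larger gain. Compound 4 shares the chain extension with compound 3 but carries a diethylamino group, a smaller change at the amine than the piperidin-1-yl of compound 3. A downward step of a size between those two is therefore expected, a 4.0-fold lower number from compound 1 to compound 4 (0.60 log units; beyond the scatter).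

Compound 4 is expected to give 180 nM, with a likely range from 70 nM to 450 nM.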

Compound 4, half-maximal inhibitory concentration: 91 nM
For compound 4 the middle estimate is 2.0-fold (0.30 log units) above the measured one, and the stated range covers the measured number.
By their numbers in this assay, from the lowest: compounds 4 and 3 (each within the scatter of the next); then compound 2; then compound 1.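

Swapping dimethylamino for 2-(diethylamino)ethyl on the saturated chain carbon, four bonds along the chain from an oxygen on an aromatic ring, gives a clear gain in this assay (a 7.9-fold lower number from compound 1 to compound 4 (0.90 log units; beyond the scatter)). The new result also shows that at the end of this chain, the ring of piperidin-1-yl is not required: the open-chain diethylamino group cannot be told apart from it (a 1.1-fold lower number from compound 3 to compound 4 (0.05 log units; within the scatter)). Compound 4 also improves on compound 2, with its longer chain ending in dimethylamino (a 3.3-fold lower number from compound 2 to compound 4 (0.51 log units; beyond the scatter)), although that step changes both the chain and the amine, so it cannot credit the gain to either one alone. No measurement shown here explains any of these differences.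

The compounds shown leave open how the gain from compound 1 to compound 4 divides between chain and amine, a split that a dimethylamino group on the chain of compound 4 would help to reveal. Also open, on these data alone, is whether other amines at the same chain end, such as morpholin-4-yl or dipropylamino, would match diethylamino and piperidin-1-yl.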